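The source may report more compounds than this note shows. Statements on the series, on what has been measured and on what is new or still open speak of the compounds shown alone.

Compound 1 `O=C(/C=C/c1ccccc1)OCC1COCCOCCOCCOCCOCCO1` is a crown-ether ester carrying a cinnamoyl group, and in a functional assay on HBL-100 cells (Homo sapiens) for inhibition, read by sulforhodamine B assay, with a stated time of 48 h (on this read-out higher numbers stand for weaker inhibition of growth and lower numbers for stronger inhibition of growth), compound 1 gives 57000 nM. Among the two compounds measured this is the lowest number, though its nearest neighbour lies within the scatter: compound 2 `O=C(CCCCCc1ccccc1)OCC1COCCOCCOCCOCCOCCO1`, which carries 5-phenylpentyl in place of 2-phenylethenyl on the carbonyl carbon, gives 64000 nM in this assay, and the step of a 1.1-fold higher number from compound 1 to compound 2 (0.05 log units; within the scatter) is within the scatter. Compound 3 `CC(=O)OCC1COCCOCCOCCOCCOCCO1` has not been measured. It differs from compound 1 by methyl in place of 2-phenylethenyl on a carbonyl carbon.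

Among the compounds with values here, the only measured step, from compound 1 to compound 2, bears on the acyl portion, yet it keeps a phenyl-bearing chain of similar length and reports no change beyond the scatter. Within the data shown here, no measured step removes the aromatic ring and shortens the acyl group to a single carbon, so the step to compound 3 has no direct precedent. A shift toward weaker inhibition of growth is expected, since the acyl portion is reduced to acetyl; the step is estimated as a 1.9-fold higher number from compound 1 to compound 3 (0.29 log units; within the scatter). Compound 3 is therefore expected to give about 110000 nM in this assay, with a plausible range from 45000 nM to 280000 nM.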

Compound 3, concentration for 50% growth inhibition: > 100000 nM
Compound 3 ended at the assay's limit; the forecaster's own chance of this, stated with the estimate: 35%; the middle value does not contradict the limit.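

Compound 3 gives > 100000 nM in this assay, and this value is a limit of the assay, not a number: the limit of > 100000 nM in this assay, at which 1 of the 3 values shown sits.

Within the data shown here, this is the first change on the carbonyl carbon that takes the aromatic ring away, and the two steps it yields are floors only: an at least 1.7-fold higher number from compound 1 to compound 3 (0.24 log units; that floor lies within the scatter), and an at least 1.5-fold higher number from compound 2 to compound 3 (0.19 log units; that floor lies within the scatter). The acetyl ester thus has no number inside the range of the assay, whereas the two acyl groups that keep a phenyl ring both do, but neither floor by itself places compound 3 beyond the scatter of compound 1 or compound 2.

From the compounds shown here alone, whether the phenyl ring itself or simply the length of the acyl group matters remains open, since a plain longer alkyl chain with no ring on the carbonyl carbon would separate the two. Going by these compounds, it is also open whether an amine or a carboxylic acid on the phenyl ring of compound 1 would move its number at all.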